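A few compounds are considered here, and "the series" means these few. Any claim that something is new, unique, unknown or untested is made for them only; others in the source may bear on it.

Measured compounds in the series:
compound 1 `CC(C)n1c(/C=C2/C(=O)Nc3ccc(Br)cc32)nc2ccccc21` — 13700 nM
compound 2 `CC(C)n1c(/C=C2/C(=O)Nc3ccc(F)cc32)nc2ccccc21` — 26700 nM
compound 3 `Cn1c(/C=C2/C(=O)Nc3ccc(Br)cc32)nc2ccccc21` — > 50000 nM (a limit of the assay)

In a functional assay on BT-549 cells (Homo sapiens) for cytotoxicity, read by MTT assay, with a stated time of 48 h (a higher number here means a weaker inhibitor, a lower number a stronger inhibitor), compound 1 gives 13700 nM and compound 2 gives 26700 nM. The difference between them is fluoro in place of bromo on an aromatic carbon, and the step it made is a 1.9-fold higher number from compound 1 to compound 2 (0.29 log units; within the scatter). For compound 3 only a limit of the assay is known, > 50000 nM. The cores of compound 1 and compound 3 differ by methyl in place of isopropyl on an aromatic nitrogen, and the step of an at least 3.6-fold higher number from compound 1 to compound 3 (0.56 log units; beyond the scatter) is known only as a bound because of the limit of > 50000 nM in this assay, at which 1 of the 3 values shown sits.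

Compound 4 `Cn1c(/C=C2/C(=O)Nc3ccc(F)cc32)nc2ccccc21` has not been measured. Among the measured compounds shown here, it differs from compound 3 by fluoro in place of bromo on an aromatic carbon, the same change as the one from compound 1 to compound 2, at the same place. Since compound 3 already stands at a limit, the expected step that the limit leaves unreadable from compound 3 to compound 4 cannot push the number downward on the basis of the pair compound 1 and compound 2, whose step a 1.9-fold higher number from compound 1 to compound 2 (0.29 log units; within the scatter) was within the scatter. Compound 4 is therefore expected to give about 90000 nM in this assay, within 45000 nM to 250000 nM, most likely again reported as a limit.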

Compound 4, half-maximal inhibitory concentration: 26900 nM
Beside the measured number, compound 4's estimate is 3.3-fold (0.52 log units) above it; the whole stated range lies above it.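

In this assay, fluoro in place of bromo on an aromatic carbon does not transfer unchanged from the core of compound 1 to the core of compound 3; on the latter the change gives an at least 1.8-fold lower number from compound 3 to compound 4 (0.26 log units; that floor lies within the scatter), and the two steps differ: the same change on two cores in this assay, a 1.9-fold higher number (0.29 log units; within the scatter) from compound 1 to compound 2 and an at least 1.8-fold lower number (0.26 log units; that floor lies within the scatter) from compound 3 to compound 4, at least 3.6-fold (0.55 log units) apart, beyond the scatter of two such steps

Methyl in place of isopropyl on an aromatic nitrogen also depends on the partner group: with fluoro on the ring it gives a 1.0-fold higher number from compound 2 to compound 4 (0.00 log units; within the scatter), so compound 2 and compound 4 cannot be told apart, and this step differs from the one with bromo on the ring: the same change on two cores in this assay, an at least 3.6-fold higher number (0.56 log units; beyond the scatter) from compound 1 to compound 3 and a 1.0-fold higher number (0.00 log units; within the scatter) from compound 2 to compound 4, at least 3.6-fold (0.55 log units) apart, beyond the scatter of two such steps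

These four compounds form a single set of paired changes, and both comparisons rest on compound 3, so they give only a floor for each gap and not its true size: the limit of > 50000 nM in this assay, at which 1 of the 4 values shown sits.

From the compounds shown here alone, it remains open whether the same dependence appears with chloro, methoxy or nitrile in place of bromo on that aromatic carbon. Ethyl, cyclopropyl or a longer chain on the aromatic nitrogen would show whether the isopropyl to methyl step is specific to those two groups.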